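Swapping chloro for acetyl in compound 2

The compounds below may be only part of what the source reports. "The series", "measured", "known", "first", "only" and "open" are said of these compounds alone.

Measured in a functional assay on L1210 cells (Mus musculus) for antiproliferative activity, read by cell counting, with a stated time of 96 h; a lower number here means a stronger inhibitor, a higher number a weaker inhibitor:
- compound 1 `CC(Nc1ccccc1Oc1cccc(F)c1)=C1C(=O)CC(c2ccccc2)CC1=O`: 330 nM
- compound 2 `CC(Nc1ccccc1Oc1ccc(Cl)cc1)=C1C(=O)CC(c2ccccc2)CC1=O`: 250 nM

Compound 2 lies within the usual scatter of compound 1, so these two cannot be ranked. Compound 3 `CC(=O)c1ccc(Oc2ccccc2NC(C)=C2C(=O)CC(c3ccccc3)CC2=O)cc1` keeps the rest of compound 2 and changes one group, with acetyl in place of chloro on an aromatic carbon. Among the measured compounds shown here, only one measured step bears on this change: a 1.3-fold lower number from compound 1 to compound 2 (0.12 log units; within the scatter). That step, 4-chlorophenyl in place of 3-fluorophenyl, stays within the scatter. For the measured compounds named here, it is thin guidance, since no measured compound carries an acetyl, so the range must stay wide. The estimated shift, a 1.4-fold higher number from compound 2 to compound 3 (0.15 log units; within the scatter), is expected to remain within the scatter, with no firm direction. In this assay, compound 3 is expected at 350 nM, with an estimated range of 120 nM to 1000 nM.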

Compound 3, half-maximal inhibitory concentration: 190 nM
Beside the measured number, compound 3's estimate is 1.8-fold (0.27 log units) above it; measured number inside the range.
By their numbers in this assay, from the lowest: compounds 3, 2 and 1 (each within the scatter of the next).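

Acetyl brings 3 heavy atoms and 1 hydrogen-bond acceptor to the position para to a large group, where chloro has 1 heavy atom and no acceptor, yet this assay shows a 1.3-fold lower number from compound 2 to compound 3 (0.12 log units; within the scatter) and so no measurable change. The 4-acetylphenyl compound also cannot be told apart from the 3-fluorophenyl compound, with a 1.7-fold lower number from compound 1 to compound 3 (0.24 log units; within the scatter) as the step between them, so this position tolerates a non-halogen group as well as the halogens seen earlier. No measurement here explains this tolerance.

From the compounds shown here alone, whether the position accepts any group is still unknown, since an amine, a carboxylic acid or a longer chain could behave differently. A group that clearly moves the number beyond the scatter remains to be found.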